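Replacing a fused aromatic ether with an oxetane ether

A few compounds are considered here, and "the series" means these few. Any claim that something is new, unique, unknown or untested is made for them only; others in the source may bear on it.

Measured compounds:
compound 1, `CC(C)(C)C#Cc1cc(N(C(=O)[C@H]2CC[C@H](C)CC2)[C@H]2CC[C@H](Oc3ccc4nccn4n3)CC2)c(C(=O)O)s1`, 133 nM
compound 2, `CC(C)(C)C#Cc1cc(N(C(=O)[C@H]2CC[C@H](C)CC2)[C@H]2CC[C@](O)(CO[C@H]3CCOC3)CC2)c(C(=O)O)s1`, 8980 nM
compound 3, `CC(C)(C)C#Cc1cc(N(C(=O)[C@H]2CC[C@H](C)CC2)[C@H]2CC[C@@H](Oc3ccc(=O)[nH]n3)CC2)c(C(=O)O)s1`, 2170 nM

The three compounds share one core and differ only in the group on the cyclohexyl ring. In an ADME assay on MT4 cells (Homo sapiens) for cytotoxicity, with a stated time of 5 days (a higher number here means that more compound is tolerated, a lower number that less compound is tolerated), compound 1 gives 133 nM, the lowest of the three numbers. Compound 3 gives 2170 nM and compound 2 gives 8980 nM; both stand well beyond the scatter above compound 1, so compound 1 is the least tolerated of the set.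

Compound 4, `CC(C)(C)C#Cc1cc(N(C(=O)[C@H]2CC[C@H](C)CC2)[C@H]2CC[C@H](OC3COC3)CC2)c(C(=O)O)s1`, is not yet measured. It differs from compound 1 in one place: a group of 4 heavy atoms (3 carbon, 1 oxygen; one four-membered non-aromatic ring with 1 hetero atom) in place of a group of 9 heavy atoms (6 carbon, 3 nitrogen; one five-membered aromatic ring with 2 hetero atoms, one six-membered aromatic ring with 2 hetero atoms), on an oxygen on a saturated carbon. In this assay the two ether-bearing analogues that do not carry the fused aromatic group, compound 2 and compound 3, both give clearly higher numbers than compound 1, so for compound 4 a step upward, beyond the scatter, is expected: a 19-fold higher number from compound 1 to compound 4 (1.27 log units; beyond the scatter). Compound 4 is estimated at 2500 nM, with a range from 800 nM to 8000 nM.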

Compound 4, half-maximal cytotoxic concentration: 8350 nM
For compound 4 the middle estimate is 3.3-fold (0.52 log units) below the measured one, outside the stated range (above it).
By their numbers in this assay, from the lowest: compound 1; then compound 3; then compounds 4 and 2 (each within the scatter of the next).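

Going by these compounds alone, this is the first pair in the set that differs in one place only, so a change on the oxygen on a saturated carbon can now be read on its own, with the rest of the molecule held constant. In this assay, oxetan-3-yl in place of the fused aromatic group gives a 63-fold higher number from compound 1 to compound 4 (1.80 log units; beyond the scatter), so this position alone can carry a large step in the number. No measurement shown explains the step.

The compounds shown leave open whether the step follows the loss of the fused aromatic group or the arrival of the oxetane itself. A cyclobutyl group or a single pyridine ring on the same oxygen would help tell these two readings apart.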